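The compounds below may be only part of what the source reports. "The series", "measured", "known", "first", "only" and "open" are said of these compounds alone.

Working notes on the series.

Three compounds have numbers in a physicochemical assay for lipophilicity, using the shake flask method, in phosphate buffer, measured as octanol-water partition, with a stated time of 30 min, at pH 7.4; a higher number here means a more lipophilic compound, a lower number a more polar compound. Compound 1 `Cc1cc(-c2cnc(NCc3c(F)ccc4c3CCO4)c3cn[nH]c(=O)c23)n(C)n1` gives 3, compound 2 `Cc1nc(CN(C)C)ccc1-c1cnc(NCc2c(F)ccc3c2CCO3)c2cn[nH]c(=O)c12` gives 2, and compound 3 `CN(C)Cc1ccc2c(c1)CN(c1cnc(NCc3c(F)ccc4c3CCO4)n3cnnc13)C2=O` gives 1.6. Among the measured compounds shown here, compound 2 therefore stands second highest of the three, with compound 3 nearest to it and compound 1 furthest from it; the single step between compounds differing in one place is a number 1.00 log units lower from compound 1 to compound 2 (beyond the scatter).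

The next compound to be measured is compound 4 `Cc1ncccc1-c1cnc(NCc2c(F)ccc3c2CCO3)c2cn[nH]c(=O)c12`. It differs from compound 2 in one place: hydrogen in place of (dimethylamino)methyl on an aromatic carbon. For the measured compounds named here, no measured pair shows exactly this change. The step from compound 1 to compound 2 is the only one that bears on it, since the group that leaves here entered there together with the change of ring, and that step was a number 1.00 log units lower from compound 1 to compound 2 (beyond the scatter) in this assay. The move from compound 2 to compound 4 is expected to run the other way, upward and beyond the scatter, though not necessarily by the full amount seen between compound 1 and compound 2.

For compound 4 the expected step is a number 1.20 log units higher from compound 2 to compound 4 (beyond the scatter). Compound 4 is estimated at 3.2, with a range from 2.6 to 3.8.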

Compound 4, distribution coefficient: 3
Compound 4: middle estimate off by 0.20 log units, on the high side; the measured number falls inside the stated range.
By their numbers in this assay, from the lowest: compound 3; then compound 2; then compounds 1 and 4 (each within the scatter of the next).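

In this assay, among the compounds shown here, the step of a number 1.00 log units higher from compound 2 to compound 4 (beyond the scatter) is the first reading of the (dimethylamino)methyl group on its own, on an aromatic carbon of the six-membered aromatic ring with 1 nitrogen, next to the ring nitrogen; in the earlier step, a number 1.00 log units lower from compound 1 to compound 2 (beyond the scatter), that group and the change of ring entered together. The change of ring now reads separately, with 2-methylpyridin-3-yl in place of 1,3-dimethyl-1H-pyrazol-5-yl giving no change at the digits printed from compound 1 to compound 4 (within the scatter), so across compounds 1, 2 and 4 the step beyond the scatter goes with the (dimethylamino)methyl group and not with the exchange of rings. No measurement in hand gives a reason for this step.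

As far as these compounds go, it remains open whether this step is particular to the (dimethylamino)methyl group or would recur with a primary aminomethyl group, a morpholinomethyl group, a carboxylic acid or a longer aminoalkyl chain at the same place. Also open, from the compounds shown here alone, is whether the (dimethylamino)methyl group would give a step of similar size on the 1,3-dimethyl-1H-pyrazol-5-yl ring, since these compounds show it on one ring only.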